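Methoxy for methyl on the fused ring of compound 3

The compounds below may be only part of what the source reports. "The series", "measured", "known", "first", "only" and "open" are said of these compounds alone.

Three compounds of the series have been run in a functional assay on Hep 3B2 cells (Homo sapiens) for antiproliferative activity, read by MTT assay, with a stated time of 24 h, tested at 33.33 ug/mL; a higher number here means a stronger effect of the compound at the concentration tested, a lower number a weaker effect. Compound 1 `Cc1ccc2nc(C(=O)Nc3c(F)cc(-c4cccc(F)c4)cc3F)c(C)c(O)c2c1` gives 37.3% in this assay. Compound 2 `Cc1c(C(=O)Nc2c(F)cc(-c3cccc(F)c3)cc2F)nc2ccc(OC(F)(F)F)cc2c1O` gives 41.3% in this assay. Compound 3 `Cc1ccc2nc(C(=O)Nc3c(F)cc(-c4cccc(F)c4)cc3F)c(C)c(C(=O)O)c2c1` gives 41.3% in this assay. The two steps from compound 1 are small: a number 4 percentage points higher from compound 1 to compound 2 (within the scatter) and a number 4 percentage points higher from compound 1 to compound 3 (within the scatter). Compound 3 thus sits level with compound 2 at the digits read, and its gap to compound 1 is within the scatter, so the three numbers cannot be ordered.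

The next compound, compound 4 `COc1ccc2nc(C(=O)Nc3c(F)cc(-c4cccc(F)c4)cc3F)c(C)c(C(=O)O)c2c1`, is built from compound 3 by methoxy in place of methyl on an aromatic carbon. Going by the values given here, one measured step bears on this change: the exchange of trifluoromethoxy for methyl on the same aromatic carbon of the fused ring, a number 4 percentage points higher from compound 1 to compound 2 (within the scatter), which lay within the scatter. Among the compounds with values here, no measured step addresses methoxy itself. On that basis no step beyond the scatter is expected in this assay for the change at hand, and the expected step is a number 0.3 percentage points lower from compound 3 to compound 4 (within the scatter). Compound 4 is therefore estimated to give 41% in this assay, with a range from 30% to 52%.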

Compound 4, a percentage reported as inhibition, at one concentration (the size of the read-out at that concentration, not a potency): 7.24%
Estimate against measurement, compound 4: 33.8 percentage points above, and the stated range ends above it.
By their numbers in this assay, from the lowest: compound 4; then compounds 1, 2 and 3 (each within the scatter of the next).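

This aromatic carbon is not indifferent to substitution in this assay: with carboxy on the shared core, methoxy in place of methyl gives a number 34.1 percentage points lower from compound 3 to compound 4 (beyond the scatter), the first step beyond the scatter among the compounds shown. The earlier exchange at the same carbon, a number 4 percentage points higher from compound 1 to compound 2 (within the scatter), brought in trifluoromethoxy on the hydroxy parent, so an oxygen-linked group here does not go with a drop in every case, but the two steps differ in both the entering group and the parent. Nothing on hand accounts for the size of the new step.

From the compounds shown here alone, whether methoxy on the hydroxy parent of compound 1, or trifluoromethoxy on the carboxy parent of compound 3, would behave in the same way stays open, so the effect of the entering group cannot yet be separated from that of the parent. Also open, going by these compounds, is how ethoxy, a chlorine atom or an amine at this carbon would read in this assay, and whether a drop seen at a single concentration carries over to a potency.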